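From Dimethylamino to Methylamino at the Assay Limit

A few compounds are considered here, and "the series" means these few. Any claim that something is new, unique, unknown or untested is made for them only; others in the source may bear on it.

Compound 1 `COCCOCn1c(Br)c(C#N)c2c(N)ncnc21`: > 100000 nM
Compound 2 `COCCOCn1cc(C#N)c2c(N)ncnc21`: > 100000 nM
Compound 3 `COCCOCn1c(N(C)C)c(C#N)c2c(N)ncnc21`: > 100000 nM

In a functional assay on KB cells (Homo sapiens) for inhibition (a lower number here means a stronger inhibitor, a higher number a weaker inhibitor), compound 3 gives > 100000 nM, which is a limit and not a number. It has no company among measured numbers, since all three results are limits: the limit of > 100000 nM in this assay, at which 3 of the 3 values shown sit.

Compound 4 `CNc1c(C#N)c2c(N)ncnc2n1COCCOC` differs from compound 3 by one small change, dimethylamino to methylamino: hydrogen in place of methyl on a nitrogen on an aromatic ring.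

Among the compounds with values here, three measured steps bear on this, as each swaps the group on the same aromatic carbon. Within the data shown here, the first is a step that the two limits leave unreadable from compound 1 to compound 2. The second is a step that the two limits leave unreadable from compound 1 to compound 3. The third is a step that the two limits leave unreadable from compound 2 to compound 3. None of them gives a size, so they point in no direction. Still, bromo, hydrogen and dimethylamino all ended at the limit in this assay, and removing a single methyl is a smaller change than those swaps. No step beyond the scatter is therefore expected, and the estimated step is a number no higher from compound 3 to compound 4 (the limit leaves the size open). Compound 4 is expected at 100000 nM. The estimated range for compound 4 runs from 50000 nM to 200000 nM.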

Compound 4, half-maximal inhibitory concentration: > 100000 nM
Compound 4 was reported as a limit; the forecaster's own chance of this, stated with the estimate: 85%; the middle value sits exactly at the limit.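

Compound 4 gives > 100000 nM, which is a limit and not a number. No step from compound 1, compound 2 or compound 3 to compound 4 can be read: the limit of > 100000 nM in this assay, at which 4 of the 4 values shown sit.

The compounds shown leave open how strongly any of the four inhibits in this assay, and whether changing the group on that aromatic carbon alters this at all.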